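Shortening the side chain of compound 1

The source may hold more compounds than are shown below. What is called first, only, known or untested is meant among the compounds shown, and "the series" means these compounds.

Measured in a functional assay on EOL1 cells (Homo sapiens) for inhibition, read by fluorescence, with a stated time of 72 h; on this read-out lower numbers stand for stronger inhibition of growth and higher numbers for weaker inhibition of growth:
compound 1 `CC(C)CCn1cnc2c(Nc3ccc(Cl)cc3)nc(N[C@H]3CC[C@H](N)CC3)nc21`: 90 nM
compound 2 `CC(C)CCn1cnc2c(Nc3cccc(Cl)c3)nc(N[C@H]3CC[C@H](N)CC3)nc21`: 60 nM

Within the data shown here, compound 1 cannot be separated from its only comparison on this assay: a 1.5-fold lower number from compound 1 to compound 2 (0.18 log units; within the scatter). The unmeasured compound 3 `CCCCn1cnc2c(Nc3ccc(Cl)cc3)nc(N[C@H]3CC[C@H](N)CC3)nc21` differs from compound 1 as follows: hydrogen in place of methyl on a saturated chain carbon bound to two saturated chain carbons. This is hydrogen in place of methyl on a saturated chain carbon bound to two saturated chain carbons, so isopentyl becomes butyl. Among the measured compounds shown here, the one measured step swaps 4-chlorophenyl for 3-chlorophenyl and leaves the chain untouched, so it offers only a weak guide, and no measured step covers this change. The expectation therefore stays anchored on compound 1 at 90 nM, with no step beyond the scatter expected in either direction. Compound 3 is estimated at 100 nM, with an expected range of 40 nM to 250 nM. The expected step is a 1.1-fold higher number from compound 1 to compound 3 (0.05 log units; within the scatter).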

Compound 3, concentration for 50% growth inhibition: 50 nM
Compound 3: middle estimate off by 2.0-fold (0.30 log units), on the high side; low and high end bracket the measured number.
By their numbers in this assay, from the lowest: compounds 3, 2 and 1 (each within the scatter of the next).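

Isopentyl to butyl is the first measured change on this side chain, and in this assay it gives (a 1.8-fold lower number from compound 1 to compound 3 (0.26 log units; within the scatter)). The methyl on the saturated chain carbon bound to two saturated chain carbons is therefore not needed to keep growth inhibition within the scatter of compound 1, so the branched chain has no measured advantage over the straight butyl chain here. Nothing at hand explains why the methyl can go without a clear effect.

As far as these compounds go, how far the chain can be shortened or lengthened remains open, for example with propyl, ethyl or hexyl, as does whether a polar terminal group such as an amine or a carboxylic acid would be tolerated at its end. Also open, from the compounds shown here alone, is whether butyl behaves the same way alongside 3-chlorophenyl.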